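A few compounds are considered here, and "the series" means these few. Any claim that something is new, unique, unknown or untested is made for them only; others in the source may bear on it.

Three compounds that share a quinazoline-like core carrying a furan-containing amine and a piperazine-bearing chain have been tested in a functional assay on DU-145 cells (Homo sapiens) for cytotoxicity, read by MTT assay, with a stated time of 2 days; a higher number here means a weaker inhibitor, a lower number a stronger inhibitor. Compound 1 `Cc1cccc(N2CCN(CCCNc3nc(NCc4ccco4)c4ccccc4n3)CC2)c1C` gives 930 nM. Compound 2 `Fc1ccc2nc(NCCCCN3CCN(c4cccc(Cl)c4Cl)CC3)nc(NCc3ccco3)c2c1` gives 670 nM. Compound 3 `Clc1cccc(N2CCN(CCCNc3nc(NCc4ccco4)c4ccccc4n3)CC2)c1Cl` gives 3710 nM. The difference between the cores of compound 2 and compound 3 is not broken down here; compound 2 and compound 1 sit within the scatter of each other, while compound 3 sits beyond the scatter from both.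

Compound 1 differs from compound 3 in one place, (2,3-dimethylphenyl in place of 2,3-dichlorophenyl on an amine nitrogen in a ring), and that change produced a 4.0-fold lower number from compound 3 to compound 1 (0.60 log units; beyond the scatter). Compound 4 `Cc1cccc(N2CCN(CCCCNc3nc(NCc4ccco4)c4cc(F)ccc4n3)CC2)c1C` has not yet been measured; it differs from compound 2 in exactly the same place and in the same way, (2,3-dimethylphenyl in place of 2,3-dichlorophenyl on an amine nitrogen in a ring). Because compound 2 already gives 670 nM and the same change gave a 4.0-fold lower number from compound 3 to compound 1 (0.60 log units; beyond the scatter), compound 4 is expected to show a 2.7-fold lower number from compound 2 to compound 4 (0.43 log units; beyond the scatter) in this assay. Compound 4 is therefore estimated at 250 nM, with a likely range from 100 nM to 650 nM, resting on a single earlier pair.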

Compound 4, half-maximal inhibitory concentration: 3320 nM
The estimate for compound 4 lay 13-fold (1.12 log units) below the measured number, outside the stated range (above it).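

In this assay, putting 2,3-dimethylphenyl in place of 2,3-dichlorophenyl gave a 5.0-fold higher number from compound 2 to compound 4 (0.70 log units; beyond the scatter). The same swap therefore moved the number in opposite directions on the two cores, so in this series its effect on one core cannot simply be carried over to another: the same change on two cores in this assay, a 4.0-fold lower number (0.60 log units; beyond the scatter) from compound 3 to compound 1 and a 5.0-fold higher number (0.70 log units; beyond the scatter) from compound 2 to compound 4, 20-fold (1.30 log units) apart, beyond the scatter of two such steps This does not show which difference between the cores goes with the reversal, as they differ in both the chain and a fluorine, and a single pair on each core cannot explain why the direction changes.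

The compounds shown leave open whether the chain or the fluorine alone sets the direction of this step. Also open, on these data alone, is how a phenyl ring bearing methoxy groups or a nitrile would behave on either core, and whether a third core, such as one with a shorter chain, would follow compound 1 or compound 4.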